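This account rests on a few compounds, and the source may have more. Where it says the series, first, only, none or still open, it means among the compounds named here.

Measured compounds so far:
Compound 1 `COc1ccc(/C=C/C(=O)c2cc(-c3ccc(OC)c(OC)c3)n3nc(-c4ccccc4)cc3n2)cc1`: in an ADME assay on HEK293 cells (Homo sapiens) for antiproliferative activity, read by MTT assay, with a stated time of 24 h (a higher number here means a weaker inhibitor, a lower number a stronger inhibitor), compound 1 gives 50700 nM.
Compound 2 `COc1ccc(-c2cc(/C=C/C(=O)c3ccc(C)cc3)nc3cc(-c4ccccc4)nn23)cc1OC`: in this assay compound 2 gives 62600 nM.
Compound 3 `COc1ccc(C(=O)/C=C/c2cc(-c3ccc(OC)c(OC)c3)n3nc(-c4ccccc4)cc3n2)cc1`: in this assay compound 3 gives 40000 nM.

Compound 1 stands second highest of these three numbers. The nearest step is a 1.2-fold higher number from compound 1 to compound 2 (0.09 log units; within the scatter) and the furthest is a 1.3-fold lower number from compound 1 to compound 3 (0.10 log units; within the scatter), so all three compounds sit together and none can be called stronger or weaker than another.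

Compound 4 `COc1ccc(/C=C/C(=O)c2cc(-c3cc(OC)c(OC)c(OC)c3)n3nc(-c4ccccc4)cc3n2)cc1` differs from compound 1 by methoxy in place of hydrogen on an aromatic carbon; the dimethoxyphenyl of compound 1 thus becomes a trimethoxyphenyl, the rest of the molecule staying the same.

Within the data shown here, no measured step touches this ring. The closest in kind is a 1.6-fold lower number from compound 2 to compound 3 (0.19 log units; within the scatter), a methoxy added in place of a methyl, though on a different ring. The other two steps, which exchange whole side groups, also stay within the scatter. Nothing measured here moves the number beyond the scatter, so for compound 4 the expected step is a 1.1-fold lower number from compound 1 to compound 4 (0.05 log units; within the scatter), that is, none beyond the scatter. The estimate for compound 4 is 45000 nM, expected to fall between 20000 nM and 110000 nM.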

Compound 4, half-maximal inhibitory concentration: 46600 nM
Beside the measured number, compound 4's estimate is 1.0-fold (0.02 log units) below it; low and high end bracket the measured number.
By their numbers in this assay, from the lowest: compounds 3, 4, 1 and 2 (each within the scatter of the next).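

The step from the 3,4-dimethoxyphenyl to the 3,4,5-trimethoxyphenyl is the only one shown on this ring, and in this assay it is a 1.1-fold lower number from compound 1 to compound 4 (0.04 log units; within the scatter) and so does not separate the two compounds. Among these compounds, this aromatic carbon, ortho to a methoxy group, therefore accepts a further methoxy in place of hydrogen with no change in the number beyond the scatter, which extends the picture from the earlier steps, all of them made elsewhere in the molecule. The data offer no independent measurement that could explain this flat result or tie it to any property of the added group.

The compounds shown leave open whether any group on this carbon can move the number beyond the scatter, since only hydrogen and methoxy appear there, and an amine, a carboxylic acid or a longer chain such as butoxy could give a different answer. They also leave open what happens when the two methoxy groups already on this ring are replaced, for example by hydroxy groups or by fluorine.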